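The source may report more compounds than this note shows. Statements on the series, on what has been measured and on what is new or still open speak of the compounds shown alone.

Measured compounds:
compound 1 `COc1cccc(/C=C/C(=O)c2sc(Nc3cccc(C)c3)nc2C)c1` — in a functional assay on Bel-7402 cells (Homo sapiens) for cytotoxicity, read by MTT assay (on this read-out lower numbers stand for stronger inhibition and higher numbers for weaker inhibition), compound 1 gives > 25000 nM, a limit of the assay.
compound 2 `Cc1cccc(Nc2nc(C)c(C(=O)/C=C/c3ccccc3Cl)s2)c1` — in this assay compound 2 gives > 25000 nM, also a limit of the assay.

Compound 2 stands at the limit of this assay and nowhere else on the numbers shown. For the measured compounds named here, the one measured step, a step that the two limits leave unreadable from compound 1 to compound 2, runs between two limits and gives no readable size; both values sit at the limit of > 25000 nM in this assay, at which 2 of the 2 values shown sit. Going by the values given here, there is thus no measured step that reads a direction or a size for any change.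

The next compound is compound 3 `Cc1ccccc1Nc1nc(C)c(C(=O)/C=C/c2ccccc2Cl)s1`, which differs from compound 2 by 2-methylphenyl in place of 3-methylphenyl on a nitrogen on an aromatic ring. Among the compounds with values here, no measured step bears on this change: the only step on hand, a step that the two limits leave unreadable from compound 1 to compound 2, is unreadable and concerns a different position of the molecule. With both measured values at the limit of this assay, the expectation for compound 3 is that it too remains at that limit, so the step that the limit leaves unreadable from compound 2 to compound 3 is expected to be none beyond the scatter. Compound 3 is therefore estimated at 40000 nM, with a range from 15000 nM to 120000 nM, and most likely reported as a limit.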

Compound 3, half-maximal inhibitory concentration: > 25000 nM
Compound 3: a limit, no number; the forecaster's own chance of this, stated with the estimate: 85%; the middle value is on the limit's open side.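

In this assay compound 3 gives > 25000 nM as a limit of the assay. No size or direction can be read for the change from 3-methylphenyl to 2-methylphenyl between compound 2 and compound 3: the limit of > 25000 nM in this assay, at which 3 of the 3 values shown sit. The compounds shown leave open whether any change on the shared core gives a readable value in this assay and which change would do so.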